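The source may hold more compounds than are shown below. What is called first, only, known or untested is meant among the compounds shown, and "the series" means these compounds.

Working notes on the series. Among the compounds with values here, the shared core of compound 1 `Cn1nc(-c2ccc(Cl)cc2)n(C)c1=S` is compared in a functional assay on the whole organism with Mus musculus as the target; a higher number here means that more compound is needed for the effect, a lower number that less compound is needed: compound 1 gives 0.27 mg/kg, the lowest of the three numbers measured so far. Compound 2 `Cn1nc(-c2ccc(Cl)c(Cl)c2)n(C)c1=S` gives 4.4 mg/kg, a change of a 16-fold higher number from compound 1 to compound 2 (1.21 log units; beyond the scatter) for chloro in place of hydrogen on an aromatic carbon. Compound 3 `CCn1c(-c2ccc(Cl)cc2)nn(C)c1=S` gives 21.2 mg/kg, a change of a 79-fold higher number from compound 1 to compound 3 (1.89 log units; beyond the scatter) for methyl in place of hydrogen on a saturated chain carbon bound to an aromatic nitrogen.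

Compound 4 `CCn1nc(-c2ccc(Cl)cc2)n(C)c1=S` has not yet been measured. It differs from compound 1 by methyl in place of hydrogen on a saturated chain carbon bound to an aromatic nitrogen. Within the data shown here, the one measured step that bears on it is the one from compound 1 to compound 3, which reads the same in words, although compound 3 and compound 4 are not the same structure, as the two drawings show. That step was large, so a large step in the same direction is expected for compound 4, with room for a smaller one since the two structures differ. Compound 4 is therefore estimated at 5 mg/kg (range 1 mg/kg to 25 mg/kg), an expected step of a 19-fold higher number from compound 1 to compound 4 (1.27 log units; beyond the scatter).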

Compound 4, dose for half-maximal effect: 100 mg/kg
Compound 4: the middle estimate sits 20-fold (1.30 log units) below what was measured; measured number outside the range, above it.
By their numbers in this assay, from the lowest: compound 1; then compound 2; then compound 3; then compound 4.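

Methyl to ethyl at this position gives a 370-fold higher number from compound 1 to compound 4 (2.57 log units; beyond the scatter), so the rise in the number seen with the same change in compound 3 is not confined to that one structure. With the step from compound 1 to compound 3 also large and in the same direction, both ethyl compounds need far more compound for the effect in this assay than the methyl compound 1 does, and this one added carbon matters a great deal on the core of compound 1. No supporting measurement is available to explain the size of this step.

The compounds shown leave open whether a propyl chain or a branched isopropyl group at this position would raise the number further. They also leave open whether a hydroxyethyl group, which carries an oxygen, would behave like ethyl.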